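Swapping the aryl amide of a benzothiazole for a trimethylpyrrole

A few compounds are considered here, and "the series" means these few. Any claim that something is new, unique, unknown or untested is made for them only; others in the source may bear on it.

Measured so far:
- compound 1 `O=C(Nc1ccc2nc(NC(=O)C3CCCCC3)sc2c1)c1ccccc1Cl`: 0.025 ug/mL
- compound 2 `O=C(Nc1ccc2nc(NC(=O)C3CCCCC3)sc2c1)c1ccc(Br)cc1`: > 4 ug/mL
- compound 3 `O=C(Nc1ccc2nc(NC(=O)C3CCCCC3)sc2c1)c1cccnc1Cl`: 0.075 ug/mL

Three compounds share one core and differ only in the aryl group on the amide carbonyl. In a functional assay on WI-38 VA13 cells (Homo sapiens) for cytotoxicity (on this read-out higher numbers stand for an effect only at larger amounts of compound and lower numbers for an effect already at smaller amounts), compound 1 gives 0.025 ug/mL, the lowest of the two numbers seen. Compound 3 sits nearest, with a 3.0-fold higher number from compound 1 to compound 3 (0.48 log units; beyond the scatter). Compound 2 reaches only a limit of the assay, > 4 ug/mL, which is the upper limit at which one of the three values sits (the limit of > 4 ug/mL in this assay, at which 1 of the 3 values shown sits). This is seen as an at least 160-fold higher number from compound 1 to compound 2 (2.20 log units; beyond the scatter) and an at least 53-fold lower number from compound 2 to compound 3 (1.72 log units; beyond the scatter): a 4-bromophenyl group on the carbonyl carbon wipes out the effect, whereas a 2-chloropyridin-3-yl group keeps most of it.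

Compound 4 `Cc1cc(C(=O)Nc2ccc3nc(NC(=O)C4CCCCC4)sc3c2)c(C)n1C` has not yet been measured. It differs from compound 1 in one place: 1,2,5-trimethyl-1H-pyrrol-3-yl in place of 2-chlorophenyl on a carbonyl carbon. Among the compounds with values here, no measured step contains a five-membered ring on this carbonyl carbon, so the nearest guides are the modest cost of a 3.0-fold higher number from compound 1 to compound 3 (0.48 log units; beyond the scatter) and the large loss of an at least 160-fold higher number from compound 1 to compound 2 (2.20 log units; beyond the scatter). Compound 4 is therefore expected to lie between those outcomes, with a loss of potency estimated as a 10-fold higher number from compound 1 to compound 4 (1.00 log units; beyond the scatter). Compound 4 is expected to give about 0.25 ug/mL in this assay, within a range from 0.03 ug/mL to 2.5 ug/mL.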

Compound 4, half-maximal effective concentration: > 6.2 ug/mL
Compound 4 ended at the assay's limit; the forecaster's own chance of this, stated with the estimate: 20%; at least 24-fold (1.39 log units) between middle value and limit.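

Compound 4 ends at a limit of this assay: the limit of > 6.2 ug/mL in this assay, at which 1 of the 4 values shown sits.

Until now, only the 4-bromophenyl group of compound 2 had shown such a loss, and the 1,2,5-trimethyl-1H-pyrrol-3-yl group on this carbonyl carbon, a five-membered ring, now does the same, seen as an at least 240-fold higher number from compound 1 to compound 4 (2.39 log units; beyond the scatter) and as an at least 82-fold higher number from compound 3 to compound 4 (1.91 log units; beyond the scatter). Among the four compounds, only the two groups that carry a chlorine, in compound 1 and compound 3, keep the effect, while the step from compound 2 to compound 4 cannot be read, with a limit on both sides.

The compounds shown leave open whether the loss in compound 4 goes with the five-membered ring itself or with its methyl groups, a question that a 1H-pyrrol-3-yl group without methyl groups would address. They also leave open whether the chlorine is needed at all, which a plain phenyl or a 2-methylphenyl group on the same carbonyl carbon would test.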